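Chloro in place of methoxy on the shared core

This account rests on a few compounds, and the source may have more. Where it says the series, first, only, none or still open, it means among the compounds named here.

Three close relatives of one core have been examined in a functional assay on CHO cells for agonist activity at Alpha-1D adrenergic receptor (Homo sapiens), read by FLIPR and calcium flux; on this read-out higher numbers stand for an effect only at larger amounts of compound and lower numbers for an effect already at smaller amounts. Compound 1 `COCc1ccccc1C1Cc2nccn2C1` carries a methoxymethyl group on its benzene ring; in this assay compound 1 gives > 10000 nM, which is a limit of the assay and not a number. Compound 2 `FC(F)Oc1ccccc1C1Cc2nccn2C1` carries a difluoromethoxy group in the same position, and in this assay compound 2 has "not determined" (no result reported). Compound 3 `COc1ccccc1C1Cc2nccn2C1` carries a methoxy group; in this assay compound 3 likewise has "not determined" (no result reported), so compound 3 stands without any number of its own. Among the measured compounds shown here, the only entry with a value in this set belongs to compound 1 (the limit of > 10000 nM in this assay, at which 1 of the 3 values shown sits). Compound 4 `Clc1ccccc1C1Cc2nccn2C1` differs from compound 3 by chloro in place of methoxy on an aromatic carbon. For the measured compounds named here, with no measured step anywhere in this set, no size or direction of change can be drawn from the data. Compound 4 is therefore expected to sit near 15000 nM in this assay, within a range from 3000 nM to 50000 nM, with a good chance that only a limit is reported.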

Compound 4, half-maximal effective concentration: 364 nM
Compound 4: the middle estimate sits 41-fold (1.61 log units) above what was measured, outside the stated range (below it).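

In this assay compound 4 gives 364 nM, the only single number among the compounds shown, so a small group on this aromatic carbon of the shared core can go with a measurable effect. Chloro in place of methoxymethyl gives an at least 27-fold lower number from compound 1 to compound 4 (1.43 log units; beyond the scatter), a clear change made by swapping a single group. The value for compound 1 is a limit of the assay and not a number, so the true step could be larger still: the limit of > 10000 nM in this assay, at which 1 of the 4 values shown sits.

Going by these compounds, the steps from compound 2 and compound 3 to compound 4 cannot be read, as neither has a reported result, and how chloro compares with methoxy or difluoromethoxy stays open. Also open, on these data alone, is what fluoro, bromo, methyl, a nitrile or an amine on the same aromatic carbon would give.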